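This account rests on a few compounds, and the source may have more. Where it says the series, first, only, none or still open, it means among the compounds named here.

Compound 2 `COc1ccc(SC)c(NCC2=NCCN2)c1` gives 101% in a functional assay for agonist activity at Alpha-1A adrenergic receptor (Homo sapiens) (on this read-out lower numbers stand for smaller maximal responses and higher numbers for larger maximal responses), level with compound 1 `CSc1ccc(C)cc1NCC1=NCCN1`, which gives 101% in this assay; the step of no change at the digits printed from compound 1 to compound 2 (within the scatter) lies within the scatter. Compound 3 `CSc1ccc(C(F)(F)F)cc1NCC1=NCCN1` differs from compound 2 by trifluoromethyl in place of methoxy on an aromatic carbon. Among the measured compounds shown here, only that one measured step bears on this change, and because it was flat no change at the digits printed from compound 1 to compound 2 (within the scatter), the expected step is likewise small, a number 3 percentage points lower from compound 2 to compound 3 (within the scatter), with no movement beyond the scatter in either direction. Compound 3 is therefore estimated to reach 98% in this assay, within a range from 82% to 110%.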

Compound 3, largest response reached (reported as maximum), in percent of the reference or control that the assay uses: 111%
Beside the measured number, compound 3's estimate is 13 percentage points below it, and the stated range ends below it.
By their numbers in this assay, from the lowest: compounds 1, 2 and 3 (each within the scatter of the next).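

At this aromatic carbon, para to a methylsulfanyl group, a third group now keeps the maximal response in this assay level: trifluoromethyl gives a number 10 percentage points higher from compound 2 to compound 3 (within the scatter), and a number 10 percentage points higher from compound 1 to compound 3 (within the scatter). This extends the flat picture to a group of 4 heavy atoms with 0 hydrogen-bond acceptors, replacing methoxy with 1 hydrogen-bond acceptor, so neither difference separates these compounds beyond the scatter. Going by these compounds, whether an amine, a carboxylic acid or a nitrile at this carbon would move the response beyond the scatter stays open. Nothing shown here explains why the response holds across these groups.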